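A Nitrile Added to a Kinase Inhibitor Scaffold

This account rests on a few compounds, and the source may have more. Where it says the series, first, only, none or still open, it means among the compounds named here.

Three compounds sharing one core were tested in a functional assay on NCI-H2228 cells (Homo sapiens) for inhibition, read by CellTiter-Glo, with a stated time of 96 h; on this read-out higher numbers stand for weaker inhibition and lower numbers for stronger inhibition. Compound 1 `CCNC(=O)c1cc(OC2CC2)c(Nc2ncc(Cl)c(Nc3cn(C)nc3S(=O)(=O)C(C)C)n2)cc1C` gives 82 nM. Compound 2 `Cc1cc(Nc2ncc(Cl)c(Nc3cn(C)nc3S(=O)(=O)C(C)C)n2)c(OC(C)C)cc1C1CCNC1` gives 364 nM. Compound 3 `CC(C)S(=O)(=O)c1nn(C)cc1Nc1nc(Nc2ccc(C3CCN(C)CC3)cc2OC2CC2)ncc1Cl` gives 36 nM, the lowest of the three numbers, with compound 1 the nearest and compound 2 the furthest, both beyond the scatter. Compound 4 `CC(C)S(=O)(=O)c1nn(C)cc1Nc1nc(Nc2cc(C#N)c(C3CCN(C)CC3)cc2OC2CC2)ncc1Cl` differs from compound 3 in one place: cyano in place of hydrogen on an aromatic carbon. Among the compounds with values here, no measured pair shows the effect of such a change, so the expectation rests on compound 3 alone. The step from compound 3 to compound 4 in this assay is expected to be a 1.3-fold higher number from compound 3 to compound 4 (0.10 log units; within the scatter), small and not clearly beyond the scatter. For compound 4 the estimated value is 45 nM, likely between 15 nM and 140 nM.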

Compound 4, half-maximal inhibitory concentration: 165 nM
The estimate for compound 4 lay 3.7-fold (0.56 log units) below the measured number; measured number outside the range, above it.
By their numbers in this assay, from the lowest: compound 3; then compounds 1 and 4 (each within the scatter of the next); then compound 2.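

In this assay a cyano group in place of hydrogen on this aromatic carbon, ortho to the 1-methylpiperidin-4-yl group and para to the cyclopropyloxy group, gives a 4.6-fold higher number from compound 3 to compound 4 (0.66 log units; beyond the scatter) and so weakens inhibition. Within the data shown here, this single change is the first direct reading of this position, and it shows that the position is sensitive to substitution. No measurement here explains the loss. On these data alone, whether an amine, a methyl or a methoxy on this carbon would weaken inhibition too remains open. So does whether the cyano group would act alike on the other compounds.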